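A few compounds are considered here, and "the series" means these few. Any claim that something is new, unique, unknown or untested is made for them only; others in the source may bear on it.

Measured so far: compound 1 `Nc1ncnc2c1ncn2C[C@@H]1CCC[C@H]1CO` gives a limit, > 200000 nM. Compound 2 `Nc1nc(N)c2nnn([C@H]3CCCC[C@H]3CO)c2n1` gives a limit, > 200000 nM. Compound 3 `Nc1nc(O)c2nnn([C@H]3CCCC[C@H]3CO)c2n1` gives a limit, > 200000 nM.

All three values come from an ADME assay on L1210/0 cells (Mus musculus) for cytotoxicity, with a stated time of 48 h (on this read-out lower numbers stand for stronger inhibition and higher numbers for weaker inhibition), and each is a limit of the assay rather than a number. The change from compound 2 to compound 3 is hydroxy in place of amino on an aromatic carbon, and its step, a step that the two limits leave unreadable from compound 2 to compound 3, cannot be read because both compounds sit at a limit; the limit of > 200000 nM in this assay, at which 3 of the 3 values shown sit, holds all three values shown. The difference between the core of compound 1 and the core of compound 2 is not broken down here.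

Compound 4 `OC[C@@H]1CCC[C@H]1Cn1cnc2c(O)ncnc21` differs from compound 1 by hydroxy in place of amino on an aromatic carbon. The surroundings differ: in the earlier pair the place is also meta to an amino group (1 heavy atom), so this is the same kind of change, not the same change. Because compound 1 and the earlier pair all sit at the limit of > 200000 nM in this assay, at which 3 of the 3 values shown sit, the step from compound 1 to compound 4 is expected to be a step that the limit leaves unreadable from compound 1 to compound 4, and compound 4 is expected to give 300000 nM, between 100000 nM and 1000000 nM.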

Compound 4, half-maximal inhibitory concentration: > 200000 nM
Compound 4 was reported as a limit (the forecaster's own chance of this, stated with the estimate: 85%); the middle value lies beyond the limit too.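

The step from compound 1 to compound 4 cannot be read, because both compounds sit at a limit of the assay: the limit of > 200000 nM in this assay, at which 4 of the 4 values shown sit. The compounds shown leave open whether, in this assay, hydroxy in place of amino on an aromatic carbon changes the read-out at all.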